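The compounds below may be only part of what the source reports. "The series", "measured", "known", "first", "only" and "open" are said of these compounds alone.

Compound 3 `COc1ccc(C(=O)/C=C/c2cc(-c3cc(OC)c(OC)c(OC)c3)n[nH]2)cc1` sits at the upper end of the three numbers measured in a functional assay on SNB-19 cells (Homo sapiens) for inhibition, read by sulforhodamine B assay, with a stated time of 48 h (on this read-out higher numbers stand for weaker inhibition of growth and lower numbers for stronger inhibition of growth), where compound 3 gives 3030 nM. Its closest neighbour is compound 2 `COc1ccc(C(=O)/C=C/c2cc(-c3cc(OC)c(OC)c(OC)c3)n[nH]2)cc1OC`, which in this assay gives 3010 nM, and the step of a 1.0-fold higher number from compound 2 to compound 3 (0.00 log units; within the scatter) lies within the scatter. The furthest is compound 1 `COc1cc(-c2cc(/C=C/C(=O)c3ccc(N)cc3)[nH]n2)cc(OC)c1OC`, which in this assay gives 9980 nM; the step of a 3.3-fold lower number from compound 1 to compound 3 (0.52 log units; beyond the scatter) is the only difference beyond the scatter among the three, and the parallel step a 3.3-fold lower number from compound 1 to compound 2 (0.52 log units; beyond the scatter) is of the same size.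

Compound 4 `COc1cc(-c2cc(/C=C/C(=O)c3ccc(F)c(F)c3)[nH]n2)cc(OC)c1OC` arises from compound 3 by the change (3,4-difluorophenyl in place of 4-methoxyphenyl on a carbonyl carbon). Going by the values given here, both measured steps at this position replaced an amino-bearing ring, and the two rings carrying methoxy groups gave numbers within the scatter of each other; no measured step swaps methoxy for fluorine. On that basis compound 4 is expected to change little, with an estimated step of a 1.2-fold higher number from compound 3 to compound 4 (0.06 log units; within the scatter) that need not exceed the scatter. Compound 4 is therefore estimated at 3500 nM, within a range from 1200 nM to 10000 nM.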

Compound 4, concentration for total growth inhibition: > 100000 nM
Compound 4: a limit, no number (the forecaster's own chance of this, stated with the estimate: 5%); at least 28-fold (1.45 log units) between middle value and limit.
By their numbers in this assay, from the lowest: compounds 2 and 3 (each within the scatter of the next); then compound 1. At a limit, above all of these: compound 4.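

Compound 4 gives no number in this assay, only a limit of the assay: the limit of > 100000 nM in this assay, at which 1 of the 4 values shown sits. The earlier compounds shown here showed only modest movement at this place on a carbonyl carbon, yet 3,4-difluorophenyl gives an at least 33-fold higher number from compound 3 to compound 4 (1.51 log units; beyond the scatter) and an at least 33-fold higher number from compound 2 to compound 4 (1.52 log units; beyond the scatter), both large. It also gives an at least 10-fold higher number from compound 1 to compound 4 (1.00 log units; beyond the scatter), so this ring stands apart from all three earlier rings, and the position proves far more sensitive to the choice of ring than the 4-methoxyphenyl and 3,4-dimethoxyphenyl pair suggested.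

The compounds shown leave open whether a single fluorine, a chlorine or a hydroxyl on this ring would stay with compounds 2 and 3 or follow compound 4. On these data alone, they also leave open how far compound 4 lies past its limit, so the true size of these steps remains unknown.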